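The compounds below may be only part of what the source reports. "The series", "measured", "known", "first", "only" and "open" are said of these compounds alone.

Compound 1 `CCN(CCCn1sc2cc(OC)c(OC)cc2c1=O)Cc1ccccc1OC` gives 15500 nM
Compound 2 `CCN(CCCn1sc2cc(OC)c(OC)cc2c1=O)Cc1ccccc1N(C)C` gives 16600 nM
Compound 3 `CCN(CCCCn1sc2cc(OC)c(OC)cc2c1=O)Cc1ccccc1OC` gives 9600 nM

All three numbers come from an assay on isolated protein for inhibition of Amine oxidase [flavin-containing] A (Homo sapiens), read by fluorescence, with a stated time of 30 min; a lower number here means a stronger inhibitor, a higher number a weaker inhibitor. Compound 1 and compound 2 share a core and differ only by dimethylamino in place of methoxy on an aromatic carbon; that change gave a 1.1-fold higher number from compound 1 to compound 2 (0.03 log units; within the scatter). Compound 3 has a different core, and the difference between the core of compound 1 and the core of compound 3 is not broken down here. Compound 4 `CCN(CCCCn1sc2cc(OC)c(OC)cc2c1=O)Cc1ccccc1N(C)C` has not yet been measured in this assay. Going by the values given here, it differs from compound 3 by dimethylamino in place of methoxy on an aromatic carbon, the same change as the one from compound 1 to compound 2, made at the same place. The expected step is a 1.1-fold higher number from compound 3 to compound 4 (0.03 log units; within the scatter), and that expectation rests on a 1.1-fold higher number from compound 1 to compound 2 (0.03 log units; within the scatter). Compound 4 is therefore estimated at 10300 nM, expected to fall between 5000 nM and 21000 nM.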

Compound 4, half-maximal inhibitory concentration: 9900 nM
For compound 4 the middle estimate is 1.0-fold (0.02 log units) above the measured one, within the range that was stated.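

Putting dimethylamino in place of methoxy on the core of compound 3 gave a 1.0-fold higher number from compound 3 to compound 4 (0.01 log units; within the scatter) in this assay, so this pair cannot be told apart. The same swap on the two cores gave steps that agree, and neither step stands out from the scatter: the same change on two cores in this assay, a 1.1-fold higher number (0.03 log units; within the scatter) from compound 1 to compound 2 and a 1.0-fold higher number (0.01 log units; within the scatter) from compound 3 to compound 4, 1.0-fold (0.02 log units) apart, within the scatter of two such steps

This shows that, on these two cores and in this assay, the swap carried over with no visible effect, but two pairs cannot show that it would do so on every core in the series, nor explain why the numbers match.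

Still open, as far as these compounds go, is whether a hydroxyl group, a fluorine atom or a carboxylic acid in the same place would give a step beyond the scatter. Also open, from the compounds shown here alone, is whether the swap would stay this small on a core with a longer chain.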